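The source may hold more compounds than are shown below. What is called first, only, known or untested is meant among the compounds shown, and "the series" means these compounds.

Measured so far in an assay on frontal cortex for displacement of a labelled ligand from corticotropin-releasing factor receptor 1 (Rattus norvegicus), with a stated time of 2 h; on this read-out lower numbers stand for stronger inhibition and higher numbers for weaker inhibition:

- compound 1, `COc1nc(C)c(Nc2nc(Cl)cn([C@H](COC(=O)c3ccccc3)C3CC3)c2=O)cc1C`, gives 1.5 nM
- compound 2, `COc1nc(C)c(Nc2nc(Cl)cn([C@H](COC(=O)c3cccnc3)C3CC3)c2=O)cc1C`, gives 5.2 nM
- compound 3, `COc1nc(C)c(Nc2nc(Cl)cn([C@H](COC(=O)Nc3ccc(Cl)cc3)C3CC3)c2=O)cc1C`, gives 1.6 nM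

Compound 3 holds the second highest number of the three. Its nearest neighbour is compound 1, with a 1.1-fold higher number from compound 1 to compound 3 (0.03 log units; within the scatter); its furthest is compound 2, with a 3.3-fold lower number from compound 2 to compound 3 (0.51 log units; beyond the scatter).

Compound 4 is `COc1nc(C)c(Nc2nc(Cl)cn([C@H](COC(=O)Nc3cc(Cl)cc(Cl)c3)C3CC3)c2=O)cc1C`. Against compound 3 the change is 3,5-dichlorophenyl in place of 4-chlorophenyl on an amide-type nitrogen. Going by the values given here, no measured step alters the substitution of the carbamate aryl; the steps known concern the carbonyl substituent as a whole, and a 1.1-fold higher number from compound 1 to compound 3 (0.03 log units; within the scatter) shows that the (4-chlorophenyl)amino carbamate sits level with the phenyl ester in this assay. The step to compound 4 is therefore expected to be small, likely within the scatter, as a 1.1-fold higher number from compound 3 to compound 4 (0.05 log units; within the scatter). For compound 4 the estimate is 1.8 nM, with a range from 0.8 nM to 4.5 nM.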

Compound 4, half-maximal inhibitory concentration: 1.7 nM
The estimate for compound 4 lay 1.1-fold (0.02 log units) above the measured number, and the stated range covers the measured number.
By their numbers in this assay, from the lowest: compounds 1, 3 and 4 (each within the scatter of the next); then compound 2.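

In this assay, 3,5-dichlorophenyl in place of 4-chlorophenyl on the amide-type nitrogen leaves the number level (a 1.1-fold higher number from compound 3 to compound 4 (0.03 log units; within the scatter)). The (3,5-dichlorophenyl)amino carbamate also stays level with the phenyl ester (a 1.1-fold higher number from compound 1 to compound 4 (0.05 log units; within the scatter)) and keeps the gap to the pyridin-3-yl ester (a 3.1-fold lower number from compound 2 to compound 4 (0.49 log units; beyond the scatter)). No measurement on hand accounts for this flat response.

From the compounds shown here alone, it remains open whether an amine or a carboxylic acid on the carbamate phenyl ring would keep the number level. Going by these compounds, a cyclohexyl group in place of that ring is equally open.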